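Swapping the Aryl Partner on a Bombesin Receptor Agonist

A few compounds are considered here, and "the series" means these few. Any claim that something is new, unique, unknown or untested is made for them only; others in the source may bear on it.

Measured compounds:
compound 1, `CCC(C)(C)Cc1c[nH]c(CCc2ccc(-c3cccc(C)n3)cc2)n1`, 105 nM
compound 2, `CCC(C)(C)Cc1c[nH]c(CCc2ccc(-c3ccncc3)cc2)n1`, 305 nM

Both compounds share the same core and differ only in the aromatic group attached to the carbon-only six-membered ring. In a functional assay on HEK293 cells for agonist activity at Bombesin receptor subtype-3 (Homo sapiens), read by luminescence and calcium flux, with a stated time of 10 min (a lower number here means that less compound is needed, a higher number that more compound is needed for the effect), compound 1 gives 105 nM, and compound 2 gives 305 nM. Among the compounds with values here, the single measured step, a 2.9-fold higher number from compound 1 to compound 2 (0.46 log units; beyond the scatter), leaves compound 2 as the higher of the two numbers, so more of it is needed for the same effect.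

Compound 3, `CCC(C)(C)Cc1c[nH]c(CCc2ccc(-n3cccn3)cc2)n1`, takes the next step from compound 2: 1H-pyrazol-1-yl in place of pyridin-4-yl on an aromatic carbon. Within the data shown here, no measured step involves a pyrazole, so the only comparison available, the step from compound 1 to compound 2, concerns a different pair of six-membered rings and bears on this change only indirectly: it shows that exchanging this aromatic partner moves the number by a modest amount. With nothing pointing clearly in either direction, a step within the usual scatter is expected, a 1.0-fold lower number from compound 2 to compound 3 (0.01 log units; within the scatter). Compound 3 is therefore estimated at 300 nM, within a range of 100 nM to 900 nM.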

Compound 3, half-maximal effective concentration: 135 nM
The estimate for compound 3 lay 2.2-fold (0.35 log units) above the measured number; the range from low to high includes it.
By their numbers in this assay, from the lowest: compounds 1 and 3 (each within the scatter of the next); then compound 2.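

In this assay, the aromatic carbon para to a large group accepts more than a six-membered ring: 1H-pyrazol-1-yl, a five-membered aromatic ring with 2 hetero atoms, gives a 2.3-fold lower number from compound 2 to compound 3 (0.35 log units; beyond the scatter), a step beyond the scatter. Set against the other pyridine, the same group gives a 1.3-fold higher number from compound 1 to compound 3 (0.11 log units; within the scatter), which lies within the scatter, so compound 1 and compound 3 cannot be told apart here even though their rings differ in size and in the number of nitrogen atoms. Nothing measured here accounts for the gap between pyridin-4-yl and 1H-pyrazol-1-yl, so the result remains an observation without an explanation.

The compounds shown leave open whether a methyl group on the pyrazole ring would shift the number, as well as how a plain phenyl ring, with no nitrogen at all, would compare. They also leave open whether this position needs an aromatic ring at all, a question that a saturated amine such as morpholine or a carboxylic acid placed on the same carbon could address.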